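The source may hold more compounds than are shown below. What is called first, only, known or untested is meant among the compounds shown, and "the series" means these compounds.

Compound 1, `O=C(NCCCCCCNc1ncnc2c1ncn2[C@@H]1O[C@H](CO)[C@@H](O)[C@H]1O)C1=CC2C=CC1CC2`, and compound 2, `O=C(NCc1ccc(Nc2ncnc3c2ncn3[C@@H]2O[C@H](CO)[C@@H](O)[C@H]2O)cc1)C1=CC2C=CC1CC2`, share the same nucleoside core and differ in the linker that carries a bicyclic amide group. Both were tested in an assay on Flp-In-CHO cells for agonist activity at adenosine receptor A1 (Homo sapiens), read by ERK phosphorylation, with a stated time of 5 min (a lower number here means a smaller maximal response, a higher number a larger maximal response), where compound 1 gives 93% and compound 2 gives 96%. Compound 2 has the higher of the two numbers, but compound 1 lies only a few points away, so the two are within the scatter and neither can be called the stronger.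

Compound 3, `OC[C@H]1O[C@@H](n2cnc3c(Nc4ccc(CN=C=S)cc4)ncnc32)[C@H](O)[C@@H]1O`, keeps the core and the aromatic ring of compound 2 and replaces the bicyclic amide end: a group of 3 heavy atoms (1 carbon, 1 nitrogen, 1 sulfur; no ring) in place of a group of 11 heavy atoms (9 carbon, 1 nitrogen, 1 oxygen; 2 six-membered non-aromatic rings of carbon only), on a saturated chain carbon bound to an aromatic carbon.

Among the measured compounds shown here, no measured pair shows what such a swap does. Both measured compounds reach close to a full response while carrying the large bicyclic group, and the new smaller group sits on the same chain carbon, so the expected step in this assay is small, in either direction, and not beyond the scatter, about a number 6 percentage points lower from compound 2 to compound 3 (within the scatter). Compound 3 is therefore estimated to reach 90%, with a likely range from 74% to 102%.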

Compound 3, largest response reached (reported as percent of maximum), in percent of the reference or control that the assay uses: 101%
Estimate against measurement, compound 3: 11 percentage points below; the measured number falls inside the stated range.
By their numbers in this assay, from the lowest: compounds 1, 2 and 3 (each within the scatter of the next).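

Among the compounds shown here, this is the first measured swap at this place, on a saturated chain carbon bound to an aromatic carbon. In this assay, putting a group of 3 heavy atoms (1 carbon, 1 nitrogen, 1 sulfur; no ring) in place of the group of 11 heavy atoms with its 2 six-membered non-aromatic rings gives a number 5 percentage points higher from compound 2 to compound 3 (within the scatter) and so leaves the response unchanged within the usual scatter. Between compound 2 and compound 3, then, the two rings and most of the bulk of the larger group are not needed for a near-full maximal response in this read-out, although nothing at hand explains why the response holds up after so large a change in the group.

On these data alone, whether the same place would accept quite different ends, such as an amine, a carboxylic acid or a longer carbon chain, stays open. Also open, as far as these compounds go, is whether the swap affects anything besides the largest response, such as how much compound is needed to reach it.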